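Amino to hydrogen on the way to compound 3

The source may hold more compounds than are shown below. What is called first, only, known or untested is meant among the compounds shown, and "the series" means these compounds.

In an ADME assay on H9 cells (Homo sapiens) for cytotoxicity, read by XTT assay, with a stated time of 6 days (a higher number here means that more compound is tolerated, a lower number that less compound is tolerated), compound 1 `Cc1cc(C)c(Oc2cc(Nc3ccc(C#N)cc3)c(N)cc2[N+](=O)[O-])c(C)c1` gives 32200 nM and compound 2 `Cc1cc(C)c(Oc2cc(Nc3ccc(C#N)cc3)c(N)cc2N)c(C)c1` gives 50000 nM as the only two results so far. These two numbers lie within the usual scatter of each other, so compound 2 cannot be told apart from compound 1 on this measure.

Compound 3 `Cc1cc(C)c(Oc2ccc(N)c(Nc3ccc(C#N)cc3)c2)c(C)c1` changes compound 2 in one place (hydrogen in place of amino on an aromatic carbon), with hydrogen in place of amino on an aromatic carbon. This is the same carbon that carries the nitro group in compound 1, so the three compounds differ in what sits there.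

Among the measured compounds shown here, one measured step bears on this. Amino in place of nitro gave a 1.6-fold higher number from compound 1 to compound 2 (0.19 log units; within the scatter) and so stayed inside the scatter. That is a single step, and it says nothing directly about a bare hydrogen at that carbon, but it gives no reason to expect a large move. The estimated step of a 1.3-fold lower number from compound 2 to compound 3 (0.10 log units; within the scatter) therefore stays within the scatter, with no firm direction expected. Compound 3 is estimated at 40000 nM with an expected range from 16000 nM to 90000 nM for now.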

Compound 3, half-maximal cytotoxic concentration: 51000 nM
Compound 3: middle estimate off by 1.3-fold (0.11 log units), on the low side; the measured number falls inside the stated range.
By their numbers in this assay, from the lowest: compounds 1, 2 and 3 (each within the scatter of the next).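

With compound 3, the carbon that carries the nitro group in compound 1 and the amino group in compound 2 holds only a hydrogen, so the position can now be read with no substituent at all. In this assay, taking away the amino group gives a 1.0-fold higher number from compound 2 to compound 3 (0.01 log units; within the scatter), and the overall swap of nitro for hydrogen gives a 1.6-fold higher number from compound 1 to compound 3 (0.20 log units; within the scatter). Among the compounds shown here, the earlier pair showed only that one group could replace another without a readable change, whereas these steps show that the same holds when nothing but hydrogen remains, so nitro, amino and hydrogen at this carbon cannot be told apart on this measure. Nothing available here explains why these three compounds sit so close together.

Still open, on these data alone, is whether a carboxylic acid or a longer chain such as a butoxy group on this carbon would also stay within the scatter of these three compounds. Also open, as far as these compounds go, is whether the amino group that remains in compound 3, para to which no substituent now sits, could be replaced by hydrogen or by a methyl group with an equally unreadable result.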